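Extending the Glycine Linker: Compound 1 to Compound 4

The compounds below may be only part of what the source reports. "The series", "measured", "known", "first", "only" and "open" are said of these compounds alone.

Compound 1 `O=C(CN(c1nc(Cl)nc2[nH]cnc12)C1CC1)NCC(=O)OCc1ccccc1`: 18.7%
Compound 2 `O=C(O)CNC(=O)CN(c1nc(Cl)nc2[nH]cnc12)C1CC1`: 32.2%
Compound 3 `C[C@H](NC(=O)CN(c1ncnc2c1ncn2C1CCCCO1)C1CC1)C(=O)OCc1ccccc1`: 55.9%

In a functional assay on the whole organism (Tail, strain ICR) with Mus musculus as the target, in the tail flick test, with a stated time of 30 min, at a dose of 25 umol/kg by the oral route (a lower number here means a weaker effect, a higher number a stronger effect of the compound at the dose given), compound 1 gives the lowest of the three numbers; compound 2 lies closer to it, compound 3 furthest away. Among the measured compounds shown here, the only step measured in one place, a number 13.5 percentage points higher from compound 1 to compound 2 (beyond the scatter), concerns the ester end and not the chain carbon changed here. Compound 4 `CSCC[C@H](NC(=O)CN(c1nc(Cl)nc2[nH]cnc12)C1CC1)C(=O)OCc1ccccc1` differs from compound 1 as follows: 2-(methylsulfanyl)ethyl in place of hydrogen on a saturated chain carbon bound to an amide-type nitrogen and a carbonyl carbon. Compound 3 carries a methyl on that carbon but also a different core, so its value cannot be separated into parts. For the measured compounds named here, with no step bearing directly on this change, a modest rise is expected for compound 4, giving an estimated a number 11.3 percentage points higher from compound 1 to compound 4 (beyond the scatter) and an expected value of 30%, within 10% to 55%.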

Compound 4, a percentage reported as activity, at one dose (the size of the read-out at that dose, not a potency): 22.2%
Beside the measured number, compound 4's estimate is 7.8 percentage points above it; measured number inside the range.
By their numbers in this assay, from the lowest: compounds 1, 4 and 2 (each within the scatter of the next, the first and the last beyond it); then compound 3.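

In this assay there is a number 3.5 percentage points higher from compound 1 to compound 4 (within the scatter) when 2-(methylsulfanyl)ethyl replaces hydrogen on a saturated chain carbon bound to an amide-type nitrogen and a carbonyl carbon. With the core of compound 1 unchanged, this carbon therefore carries a group of 4 heavy atoms with no shift beyond the scatter at this dose. No measured evidence bears on why this is so. On these data alone, whether an amine, a carboxylic acid or a longer chain on this carbon would shift the number remains open. So does whether 2-(methylsulfanyl)ethyl would behave alike with the free acid end of compound 2.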